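Oxan-4-yl in place of ethyl on the ring amine

The compounds below may be only part of what the source reports. "The series", "measured", "known", "first", "only" and "open" are said of these compounds alone.

Compound 1, `Cc1cccc(NC(=O)[C@H]2CN(C)C[C@@H]2c2ccc(/C=C/C(=O)Nc3ccccc3N)cc2)c1`: 74 mL/min/kg
Compound 2, `CCN1C[C@H](C(=O)Nc2ccc(Cl)cc2)[C@@H](c2ccc(/C=C/C(=O)Nc3ccccc3N)cc2)C1`: 35 mL/min/kg

Of the compounds shown here, two have been measured in an in vitro ADME assay on microsomes from liver (Mus musculus) for pharmacokinetics, read by LC-MS, with a stated time of 10 min, tested at 1 uM; a lower number here means slower removal, a higher number faster removal of the compound. In this assay compound 1 gives 74 mL/min/kg, while compound 2 gives 35 mL/min/kg, the lower of the two numbers, and the gap between them lies beyond the usual scatter. Compound 3, `Nc1ccccc1NC(=O)/C=C/c1ccc([C@H]2CN(C3CCOCC3)C[C@@H]2C(=O)Nc2ccc(Cl)cc2)cc1`, has not yet been measured. It differs from compound 2 in one place: oxan-4-yl in place of ethyl on an amine nitrogen in a ring. Among the measured compounds shown here, no step between measured compounds shows what this exchange does to clearance, so the expectation for compound 3 rests on compound 2 alone. The step from compound 2 to compound 3 is expected to be small, a 1.2-fold lower number from compound 2 to compound 3 (0.07 log units; within the scatter), within the scatter rather than a clear shift in either direction. Compound 3 is therefore expected to give about 30 mL/min/kg, with a range from 15 mL/min/kg to 60 mL/min/kg.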

Compound 3, clearance: 44 mL/min/kg
Compound 3: middle estimate off by 1.5-fold (0.17 log units), on the low side; measured number inside the range.
By their numbers in this assay, from the lowest: compounds 2, 3 and 1 (each within the scatter of the next, the first and the last beyond it).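

In this assay, among the compounds shown here, the first reading of a change at this position gives a 1.3-fold higher number from compound 2 to compound 3 (0.10 log units; within the scatter), with oxan-4-yl, which brings a six-membered non-aromatic ring and a hydrogen-bond acceptor, in place of ethyl on the ring amine. With the (4-chlorophenyl)carbamoyl group held constant, this amine nitrogen therefore accepts a much larger substituent with no shift in clearance beyond the scatter. Nothing available accounts for this outcome or links it to any property of either group.

Going by these compounds, compound 1 differs from compound 2 and compound 3 in more than one place, so whether the same exchange would behave alike with its 3-methylphenyl amide remains open. Also open, on these data alone, is whether a piperidin-4-yl group, an acetyl group or a longer chain on this nitrogen would stay within the scatter of compound 2.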